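Shortening the Chain on the Ring Nitrogen: Cytotoxicity Outlook

The source may report more compounds than this note shows. Statements on the series, on what has been measured and on what is new or still open speak of the compounds shown alone.

Compound 1, `CCC(C)CN(c1ccnc(Nc2ccc(C#N)cc2)n1)c1c(F)cc(-c2ccc(C#N)cc2)cc1F`: > 255000 nM
Compound 2, `N#Cc1ccc(Nc2nccc(N(CCCCl)c3c(F)cc(-c4ccc(C#N)cc4)cc3F)n2)cc1`: > 250000 nM

In an ADME assay on MT4 cells (Homo sapiens) for cytotoxicity, read by MTT assay, with a stated time of 5 days (on this read-out lower numbers stand for higher toxicity in this test and higher numbers for lower toxicity in this test), compound 1 gives > 255000 nM, which is a limit of the assay and not a number. In this assay compound 2 gives > 250000 nM, likewise a limit. Because both values are limits, a step that the two limits leave unreadable from compound 1 to compound 2 cannot be read; the two limits are the limit of > 250000 nM in this assay, at which 1 of the 2 values shown sits, and (the limit of > 255000 nM in this assay, at which 1 of the 2 values shown sits). Compound 2 therefore stands only at a limit, with no measured toxicity within the tested range.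

Compound 3, `C=CCN(c1ccnc(Nc2ccc(C#N)cc2)n1)c1c(F)cc(-c2ccc(C#N)cc2)cc1F`, differs from compound 2 by vinyl in place of 2-chloroethyl on a saturated chain carbon bound to a nitrogen on an aromatic ring. For the measured compounds named here, the only measured step, from compound 1 to compound 2, touches the same position and left no readable size, so no step beyond the scatter in this assay can be expected from this change. Compound 3 is expected to sit at 250000 nM, within 100000 nM to 300000 nM, which means an expected step of a number no higher from compound 2 to compound 3 (the limit leaves the size open) from compound 2, most probably again reported only as a limit.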

Compound 3, half-maximal cytotoxic concentration: 249000 nM
Estimate against measurement, compound 3: 1.0-fold (0.00 log units) above; the range from low to high includes it.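

In this assay, for the compounds shown here, compound 3 gives 249000 nM, the only value among the three compounds that is a number and not a limit. Vinyl in place of sec-butyl on a saturated chain carbon bound to a nitrogen on an aromatic ring gives an at least 1.0-fold lower number from compound 1 to compound 3 (0.01 log units; that floor lies within the scatter), and the true size of that step stays open, as only its floor is known. Vinyl in place of 2-chloroethyl gives a number no higher from compound 2 to compound 3 (the limit leaves the size open), and the size of that step cannot be read, as one of its two values is a limit: the limit of > 250000 nM in this assay, at which 1 of the 3 values shown sits.

With one number and two limits, the compounds shown fix the size of no change at this position. On these data alone, whether an amine or a carboxylic acid on this chain would give a clearly lower number stays open.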